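Hydroxy to Methoxymethoxy on Compound 2

A few compounds are considered here, and "the series" means these few. Any claim that something is new, unique, unknown or untested is made for them only; others in the source may bear on it.

In a functional assay on MCF7 cells (Homo sapiens) for antiproliferative activity, read by MTT assay (on this read-out lower numbers stand for stronger inhibition and higher numbers for weaker inhibition), compound 1 (`CC/C=C\C/C=C\C/C=C\CCCCCCCc1cc(=O)c2c(O)cc(OCOC)c(C)c2o1`) gives 17500 nM and compound 2 (`CCCCCCCCCCCCCCCc1cc(=O)c2c(O)cc(O)c(C)c2o1`) gives 17500 nM, so the two stand level. Compound 3 (`CCCCCCCCCCCCCCCc1cc(=O)c2c(O)cc(OCOC)c(C)c2o1`) has not yet been measured. It differs from compound 2 in one place: methoxymethyl in place of hydrogen on an oxygen on an aromatic ring. This puts methoxymethyl in place of hydrogen on an oxygen on an aromatic ring, turning hydroxy to methoxymethoxy.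

Among the compounds with values here, no measured pair shows this change on its own in this assay, so any forecast is tentative. Compound 1 also carries methoxymethoxy and gives 17500 nM, level with compound 2, so no shift beyond the scatter is expected in either direction. The expected step is a 1.1-fold higher number from compound 2 to compound 3 (0.04 log units; within the scatter), which is estimated to stay within the scatter. Compound 3 is estimated at 19000 nM, with an expected range from 8500 nM to 42000 nM.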

Compound 3, half-maximal inhibitory concentration: > 67200 nM
Compound 3: a limit, no number (the forecaster's own chance of this, stated with the estimate: 12%); at least 3.5-fold (0.54 log units) between middle value and limit.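

In this assay compound 3 gives > 67200 nM, which is a limit of the assay and not a number. Within the data shown here, on the saturated chain, turning hydroxy to methoxymethoxy gives an at least 3.8-fold higher number from compound 2 to compound 3 (0.58 log units; beyond the scatter), so this oxygen on an aromatic ring is not indifferent to the change, as the earlier compounds had suggested. With methoxymethoxy held fixed, a group of 8 heavy atoms in place of a group of 10 heavy atoms on the chain gives an at least 3.8-fold higher number from compound 1 to compound 3 (0.58 log units; beyond the scatter), so methoxymethoxy does not by itself set the level, and the chain counts as well.

The compounds shown leave open how large the loss truly is, since only a limit bounds it. They also leave open whether a plain methyl on this oxygen would cost as much as methoxymethyl, and how hydroxy behaves on the chain of compound 1.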